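A few compounds are considered here, and "the series" means these few. Any claim that something is new, unique, unknown or untested is made for them only; others in the source may bear on it.

Measured so far, in a functional assay on HL-60 cells (Homo sapiens) for cytotoxicity, read by WST assay, with a stated time of 48 h; a lower number here means a stronger inhibitor, a higher number a weaker inhibitor:

- Compound 1 `COc1cccc(/C=C/C[C@H]2C[C@@H]([C@@H](O)c3ccccc3)CO[C@@H]2c2ccccc2)c1` gives 9620 nM.
- Compound 2 `O=[N+]([O-])c1ccccc1/C=C/C[C@H]1C[C@@H]([C@@H](O)c2ccccc2)CO[C@@H]1c1ccccc1` gives 7250 nM.

Compound 1 carries the larger of these two numbers, yet the step of a 1.3-fold lower number from compound 1 to compound 2 (0.12 log units; within the scatter) means the two compounds cannot be told apart in this assay. Both share the same core and differ only in the aromatic ring at the end of the chain.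

Compound 3 `C=CC[C@H]1C[C@@H]([C@@H](O)c2ccccc2)CO[C@@H]1c1ccccc1` has not been measured. It differs from compound 1 in one place: vinyl in place of 2-(3-methoxyphenyl)ethenyl on a saturated chain carbon bound to a saturated ring carbon. Here the whole aromatic ring and its methoxy group are cut away, leaving only the short chain.

Among the compounds with values here, the one measured step swaps one aromatic ring for another and changes nothing beyond the scatter, so it says little about removing the ring altogether. Within the data shown here, no measured pair shows what the ring itself contributes. With so little to go on, the expectation is a modest weakening, giving an estimated step of a 2.1-fold higher number from compound 1 to compound 3 (0.32 log units; beyond the scatter) with wide uncertainty. Compound 3 is therefore expected to give about 20000 nM, in a range from 7000 nM to 60000 nM.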

Compound 3, half-maximal inhibitory concentration: 36000 nM
The estimate for compound 3 lay 1.8-fold (0.26 log units) below the measured number; measured number inside the range.
By their numbers in this assay, from the lowest: compounds 2 and 1 (each within the scatter of the next); then compound 3.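

Cutting 2-(3-methoxyphenyl)ethenyl back to vinyl, on a saturated chain carbon bound to a saturated ring carbon, gives the first change in this assay that lies beyond the scatter: a 3.7-fold higher number from compound 1 to compound 3 (0.57 log units; beyond the scatter) is the step. The earlier exchange of one aromatic ring for another moved the number only within the scatter, so the new result adds that losing the ring and its methoxy group altogether does weaken the compound, though only modestly, and the shorter compound 3 still has a measured number. No measurement shown here explains this loss, so it stands as an observation without a known cause.

With the ring and the chain length changed in one step, the compounds shown cannot tell whether the aromatic ring itself matters or simply the reach of the group. A longer chain of plain carbon with no ring would separate those two readings, and an amine or a carboxylic acid at the end of the chain would test a quite different kind of group at this position.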